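Acetyl for ethylsulfonyl: what clearance to expect

A few compounds are considered here, and "the series" means these few. Any claim that something is new, unique, unknown or untested is made for them only; others in the source may bear on it.

Compound 1 `Cn1cc(C(=O)N2CC3(C2)CN(c2cncc(N4C(=O)c5ccc(Cl)cc5C4(C)C)c2)C3)cn1` gives 6.4 mL/min/kg in clearance
Compound 2 `CCS(=O)(=O)N1CC2(CN(c3cncc(N4C(=O)c5ccc(Cl)cc5C4(C)C)c3)C2)C1` gives 0.87 mL/min/kg in clearance

In an ADME assay on microsomes from liver (Rattus norvegicus) for metabolic stability, read by LC-MS, using NADPH, with stated times of 10 min and 30 min (on this read-out lower numbers stand for slow clearance and higher numbers for fast clearance), compound 2 stands at the lower of the two numbers, with 0.87 mL/min/kg against compound 1 at 6.4 mL/min/kg on the same read-out.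

Compound 3 (`CC(=O)N1CC2(C1)CN(c1cncc(N3C(=O)c4ccc(Cl)cc4C3(C)C)c1)C2`) has not yet been measured. It differs from compound 2 by acetyl in place of ethylsulfonyl on an amine nitrogen in a ring.

Among the measured compounds shown here, only one measured step bears on this change. It falls at the same nitrogen and is modest but beyond the scatter (a 7.4-fold lower number from compound 1 to compound 2 (0.87 log units; beyond the scatter)). For the measured compounds named here, compound 3 returns to a carbonyl on that nitrogen, as in compound 1, but no measured compound carries acetyl, so that step can serve only as a rough guide. A move to a higher number in this assay is therefore expected, smaller than the measured step and uncertain in size. The expected change is (a 2.3-fold higher number from compound 2 to compound 3 (0.36 log units; beyond the scatter)).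

The estimated clearance for compound 3 is 2 mL/min/kg (range 0.8 mL/min/kg to 5.5 mL/min/kg).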

Compound 3, clearance: 3.71 mL/min/kg
Estimate against measurement, compound 3: 1.9-fold (0.27 log units) below; the measured number falls inside the stated range.
By their numbers in this assay, from the lowest: compound 2; then compounds 3 and 1 (each within the scatter of the next).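

In this assay, acetyl in place of ethylsulfonyl on the amine nitrogen in a ring gives a 4.3-fold higher number from compound 2 to compound 3 (0.63 log units; beyond the scatter) and so shows that a second carbonyl group, and not only the (1-methyl-1H-pyrazol-4-yl)carbonyl group of compound 1, stands apart from ethylsulfonyl on this read-out. At the carbonyl carbon, methyl in place of 1-methyl-1H-pyrazol-4-yl gives a 1.7-fold lower number from compound 1 to compound 3 (0.24 log units; within the scatter) and leaves compound 1 and compound 3 within the scatter of each other, so for these two groups the change at that carbon does not separate the compounds, while ethylsulfonyl differs from both by more than the scatter. Nothing available on these compounds accounts for this difference between ethylsulfonyl and the two carbonyl groups.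

The compounds shown leave open whether another sulfonyl group, such as methylsulfonyl or cyclopropylsulfonyl, would stay with ethylsulfonyl, and whether a urea or a longer acyl chain such as propanoyl would stay with acetyl. They also leave open whether the same gap would appear on a core other than the one shared by these three compounds.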